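The source may hold more compounds than are shown below. What is called first, only, known or untested is meant among the compounds shown, and "the series" means these compounds.

Compound 1 `O=C(/C=C(/C=C/c1ccc(O)cc1)NCCCO)/C=C/c1ccc(O)cc1`: 154000 nM
Compound 2 `COCCNC(=C\C(=O)/C=C/c1ccc(O)cc1)/C=C/c1ccc(O)cc1`: > 200000 nM

These values come from a functional assay, read by spectrophotometry, with a stated time of 30 min; on this read-out higher numbers stand for an effect only at larger amounts of compound and lower numbers for an effect already at smaller amounts. Compound 2 gives > 200000 nM, which is a limit of the assay and not a number. Compound 3 `O=C(/C=C(/C=C/c1ccc(O)cc1)NCCO)/C=C/c1ccc(O)cc1` differs from it by hydrogen in place of methyl on an oxygen on a saturated carbon: hydrogen in place of methyl on an oxygen, or methoxy to hydroxy. Within the data shown here, the only measured step that bears on this, an at least 1.2-fold higher number from compound 1 to compound 2 (0.11 log units; that floor lies within the scatter), gives just a floor and so fixes no size. A small move to a lower number is expected because compound 1 with its hydroxy group gives 154000 nM. The expected step is an at least 1.4-fold lower number from compound 2 to compound 3 (0.15 log units; that floor lies within the scatter), and it may stay within the scatter. For compound 3 the estimate is 140000 nM, with an expected range of 80000 nM to 200000 nM.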

Compound 3, half-maximal effective concentration: > 200000 nM
Compound 3 was reported as a limit; the forecaster's own chance of this, stated with the estimate: 35%; middle value at least 1.4-fold (0.15 log units) from the limit.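

In this assay compound 3 gives > 200000 nM, which is a limit of the assay and not a number. Among these compounds, the step between the two limits cannot be read, and the one readable step, an at least 1.2-fold higher number from compound 1 to compound 3 (0.11 log units; that floor lies within the scatter), is only a floor. So a hydroxy group does not by itself bring a 2-hydroxyethyl compound to a readable value, and the series now gathers at one point: the limit of > 200000 nM in this assay, at which 2 of the 3 values shown sit.

On these data alone, whether 2-hydroxyethyl or 2-methoxyethyl is the better group stays open. So does what an amine, a carboxylic acid or a longer chain would give in place of the hydroxy group.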